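Shortening a chain, then trading an amine for an amide

The source may report more compounds than this note shows. Statements on the series, on what has been measured and on what is new or still open speak of the compounds shown alone.

Compound 2 `NCCCc1c[nH]c2c(F)cccc12` is measured in an assay on isolated protein (urine) for inhibition of Myeloperoxidase (Homo sapiens), with a stated time of 5 min (a lower number here means a stronger inhibitor, a higher number a weaker inhibitor), where compound 2 gives 24 nM. That is the highest of the two numbers reported: compound 1 `NCCCCc1c[nH]c2c(F)cccc12` gives 6 nM, and the step of a 4.0-fold higher number from compound 1 to compound 2 (0.60 log units; beyond the scatter) shows that losing one chain carbon already weakens inhibition beyond the scatter. A third compound, compound 3 `NCCCc1c[nH]c2ccc(C(=O)O)cc12`, which carries a carboxylic acid instead of the fluorine, is reported in this assay as "not active" (no number reported), with no number given.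

The unmeasured compound 4 `NC(=O)CCc1c[nH]c2c(F)cccc12` differs from compound 2 as follows: carbamoyl in place of aminomethyl on a saturated chain carbon, two bonds along the chain from an aromatic carbon. The amine that is kept in compounds 1 and 2 is thus replaced by a carbamoyl group. No measured step among these compounds changes the amine itself, so the only guide is indirect: the chain-shortening step a 4.0-fold higher number from compound 1 to compound 2 (0.60 log units; beyond the scatter) shows that even a small change to this part of the molecule costs activity, and the one compound without an amine and without the fluorine, compound 3, returned no number at all. Compound 4 is therefore expected to be a markedly weaker inhibitor, with a step of a 130-fold higher number from compound 2 to compound 4 (2.10 log units; beyond the scatter), and a real chance that only a limit is reported. For compound 4 the estimate in this assay is 3000 nM, between 400 nM and 30000 nM.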

Compound 4, half-maximal inhibitory concentration: 271 nM
Estimate against measurement, compound 4: 11-fold (1.04 log units) above, and the stated range ends above it.
By their numbers in this assay, from the lowest: compound 1; then compound 2; then compound 4.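

In this assay, carbamoyl in place of aminomethyl on the saturated chain carbon gives an 11-fold higher number from compound 2 to compound 4 (1.05 log units; beyond the scatter), a larger step than the one seen on losing a chain carbon, a 4.0-fold higher number from compound 1 to compound 2 (0.60 log units; beyond the scatter), and measured against the longer amine chain the change amounts to a 45-fold higher number from compound 1 to compound 4 (1.65 log units; beyond the scatter). The loss is large but not complete: compound 4 still gives 271 nM, so among the compounds shown a chain end without the amine keeps a measurable number, although compound 1 and compound 2, which carry the amine, give the lower numbers. No available information accounts for the size of this step.

The compounds shown do not separate the effect of adding the carbonyl from that of losing the amine, as none of them ends its chain in a hydroxyl group or a simple alkyl group. Also open, as far as these compounds go, is how a longer chain ending in carbamoyl, or a carboxylic acid in place of the carbamoyl on the same chain, would compare with compound 4 in this assay.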